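The source may hold more compounds than are shown below. What is called first, only, known or untested is meant among the compounds shown, and "the series" means these compounds.

Measured in a functional assay on NCI-H460 cells (Homo sapiens) for antiproliferative activity, with a stated time of 72 h; on this read-out lower numbers stand for stronger inhibition and higher numbers for weaker inhibition:
- compound 1 `CCCC#Cc1cc([C@@H]2O[C@H](CO)[C@@H](O)[C@H]2O)n2ncnc(N)c12`: 400 nM
- compound 2 `Nc1ncnn2c([C@@H]3O[C@H](CO)[C@@H](O)[C@H]3O)cc(C#Cc3ccc(F)cc3)c12`: 79400 nM
- compound 3 `Nc1ncnn2c([C@@H]3O[C@H](CO)[C@@H](O)[C@H]3O)cc(C#Cc3cccs3)c12`: 26600 nM

Compound 2 has the highest number of the three, and so the weakest inhibition. Compound 4 `Nc1ncnn2c([C@@H]3O[C@H](CO)[C@@H](O)[C@H]3O)cc(-c3ccccc3)c12` carries phenyl in place of 2-(4-fluorophenyl)ethynyl on an aromatic carbon. Among the compounds with values here, no measured step removes the triple bond, so the evidence is indirect. The large steps of a 200-fold higher number from compound 1 to compound 2 (2.30 log units; beyond the scatter) and a 67-fold higher number from compound 1 to compound 3 (1.82 log units; beyond the scatter) show what replacing propyl with a ring did, while the step of a 3.0-fold lower number from compound 2 to compound 3 (0.47 log units; beyond the scatter) was only modest. Compound 4 also ends in a ring, so it is expected to stay near compound 3 at 26600 nM in this assay. A modest fall is expected, estimated as a 3.2-fold lower number from compound 2 to compound 4 (0.50 log units; beyond the scatter). For compound 4 the estimated value is 25000 nM, with an expected range of 5000 nM to 100000 nM.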

Compound 4, half-maximal inhibitory concentration: > 100000 nM
Compound 4: only a limit was reported (the forecaster's own chance of this, stated with the estimate: 20%); middle value at least 4.0-fold (0.60 log units) away from the limit.
By their numbers in this assay, from the lowest: compound 1; then compound 3; then compound 2. At a limit, above all of these: compound 4.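

In this assay, compound 4 is reported only as a limit: the limit of > 100000 nM in this assay, at which 1 of the 4 values shown sits. A phenyl set directly on this aromatic carbon, without a triple bond, brought no return towards the low number of the pent-1-yn-1-yl compound, with steps of an at least 3.7-fold higher number from compound 3 to compound 4 (0.57 log units; beyond the scatter) and an at least 250-fold higher number from compound 1 to compound 4 (2.39 log units; beyond the scatter). The remaining step, an at least 1.2-fold higher number from compound 2 to compound 4 (0.10 log units; that floor lies within the scatter), does not separate those two compounds.

Going by these compounds, it remains open whether a pentyl chain with no triple bond, an amine or a carboxylic acid on this carbon would give a low number. On these data alone, it is equally open how a longer chain on the triple bond would read.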